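What a 2-(propylamino)ethyl group may do for compound 2

The source may report more compounds than this note shows. Statements on the series, on what has been measured and on what is new or still open speak of the compounds shown alone.

In a functional assay on L1210 cells (Mus musculus) for inhibition, with a stated time of 48 h (a higher number here means a weaker inhibitor, a lower number a stronger inhibitor), compound 2 (`CCCNCCCCNCCCN`) reads > 100000 nM as a limit, so it has no measured number. Compound 1 (`CCNCCCCNCCCN`) also reads > 100000 nM as a limit. Compound 3 (`CCNCCCCCNCCCCNCC`), by contrast, gives a measured 4500 nM in this assay as its number.

Compound 4 (`CCCNCCCCCNCCCCNCCC`) carries 2-(propylamino)ethyl in place of amino on a saturated chain carbon, three bonds along the chain from an amine nitrogen, and 2-(propylamino)ethyl in place of amino on a saturated chain carbon, three bonds along the chain from an amine nitrogen gives that change in full.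

The step that the two limits leave unreadable from compound 1 to compound 2 offers no guidance on size. The closest guide is an at least 22-fold lower number from compound 1 to compound 3 (1.34 log units; beyond the scatter) for a change that put 2-(ethylamino)ethyl in place of amino at that same kind of place. A similarly large move toward a lower number is therefore expected here, although the limit for compound 2 leaves its exact size open. The expected step is an at least 25-fold lower number from compound 2 to compound 4 (1.39 log units; beyond the scatter) in this assay on this reasoning. For compound 4 the estimated value is 4000 nM with an expected range of 700 nM to 30000 nM around it.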

Compound 4, half-maximal inhibitory concentration: 100000 nM
Beside the measured number, compound 4's estimate is 25-fold (1.40 log units) below it, outside the stated range (above it).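

Putting 2-(propylamino)ethyl in place of amino at this place gives, in this assay, a number no higher from compound 2 to compound 4 (the limit leaves the size open). The earlier compounds shown here showed only the 2-(ethylamino)ethyl change, with an at least 22-fold lower number from compound 1 to compound 3 (1.34 log units; beyond the scatter), so a large move could have seemed general to this kind of place; the new pair does not show such a move, and a related group at the same kind of place need not repeat it. The size of the new step cannot be read because compound 2 is recorded only as a limit: the limit of > 100000 nM in this assay, at which 2 of the 4 values shown sit.

The compounds shown leave open how a 2-(methylamino)ethyl or a 2-(butylamino)ethyl group would read at this place. They also leave open whether a measured number for compound 2 would reveal any real step at all.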